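The compounds below may be only part of what the source reports. "The series", "measured", "known", "first", "only" and "open" are said of these compounds alone.

Measured so far in a physicochemical assay for pharmacokinetics, at 37 degrees C; on this read-out lower numbers stand for a shorter-lived compound and higher numbers for a longer-lived compound:
compound 1 `CO[C@H]1C(=O)N2C(C(=O)c3ccccc3)=C(C)C(Sc3nnnn3C)S(=O)(=O)[C@H]12` gives 120 h;
compound 2 `CO[C@H]1C(=O)N2C(C(=O)C(C)(C)C)=C(CSc3nnnn3C)CS(=O)(=O)[C@H]12` gives 24 h;
compound 3 `CO[C@H]1C(=O)N2C(C(=O)C(C)(C)C)=C(CSc3nnnn3C)C(Sc3nnnn3C)S(=O)(=O)[C@H]12` gives 24 h.

Compound 1 stands highest of the three, while compound 2 and compound 3 sit at the same number. The difference between the core of compound 1 and the core of compound 3 is not broken down here.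

Between compound 3 and compound 2 one change is made: hydrogen in place of (1-methyl-1H-tetrazol-5-yl)sulfanyl on a saturated ring carbon. That change made this step: no change at the digits printed from compound 3 to compound 2 (within the scatter).

The unmeasured compound 4 `CO[C@H]1C(=O)N2C(C(=O)c3ccccc3)=C(C)CS(=O)(=O)[C@H]12` comes from compound 1 by the same kind of change: hydrogen in place of (1-methyl-1H-tetrazol-5-yl)sulfanyl on a saturated ring carbon. The surroundings differ, though: in compound 1 the carbon that loses the group sits next to the ring atom that bears a methyl group, two ring bonds from the ring atom that bears a benzoyl group, whereas in compound 3 those ring atoms bear a ((1-methyl-1H-tetrazol-5-yl)sulfanyl)methyl group and a (tert-butyl)carbonyl group.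

Because no change at the digits printed from compound 3 to compound 2 (within the scatter) showed no change within the scatter, the step from compound 1 to compound 4 is expected to be about as small, a 1.1-fold lower number from compound 1 to compound 4 (0.04 log units; within the scatter). Compound 4 is therefore estimated at 110 h, with a likely range from 55 h to 220 h.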

Compound 4, half-life: 33 h
The estimate for compound 4 lay 3.3-fold (0.52 log units) above the measured number, outside the stated range (below it).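

In this assay, putting hydrogen in place of (1-methyl-1H-tetrazol-5-yl)sulfanyl on a saturated ring carbon gives a 3.6-fold lower number from compound 1 to compound 4 (0.56 log units; beyond the scatter) on one core, while the same change on the other core gives no change at the digits printed from compound 3 to compound 2 (within the scatter), so in this series the size of the step did not carry from one core to the other. This is a single pair of steps, and the two cores differ in two places, a methyl group against a ((1-methyl-1H-tetrazol-5-yl)sulfanyl)methyl group and a benzoyl group against a (tert-butyl)carbonyl group, so it does not show which of these goes with the different result. Nothing measured here explains the gap between the two steps.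

From the compounds shown here alone, a compound pairing the benzoyl group with the ((1-methyl-1H-tetrazol-5-yl)sulfanyl)methyl group, or the (tert-butyl)carbonyl group with the methyl group, would separate those two places, and its behaviour remains open. Also open, going by these compounds, is how an amine or a carboxylic acid on that same saturated ring carbon would compare with hydrogen and with the (1-methyl-1H-tetrazol-5-yl)sulfanyl group.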